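Swapping the Amide-Bearing Ring on a Kinase Inhibitor Core

This account rests on a few compounds, and the source may have more. Where it says the series, first, only, none or still open, it means among the compounds named here.

Measured compounds:
- compound 1, `N#Cc1cnc(NCc2cnccc2C(F)(F)F)cc1N[C@H]1C[C@H](O)C1`: in an assay on isolated protein for inhibition of protein kinase C delta type (Homo sapiens), read by TR-FRET, with a stated time of 2 h (on this read-out higher numbers stand for weaker inhibition and lower numbers for stronger inhibition), compound 1 gives > 10000 nM
- compound 2, `CNC(=O)[C@H]1CC[C@@H](Nc2cc(NCc3cnccc3C(F)(F)F)ncc2C#N)CC1`: in this assay compound 2 gives 1600 nM

The value of compound 1 is a limit of the assay, not a measured number. Compound 2 therefore stands alone as the only actual number shown, and the single measured step, an at least 6.2-fold lower number from compound 1 to compound 2 (0.79 log units; beyond the scatter), shows that moving from 3-hydroxycyclobutyl to an amide-bearing ring on the nitrogen on the aromatic ring helped, at least modestly; the lower end of that step rests on (the limit of > 10000 nM in this assay, at which 1 of the 2 values shown sits).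

Compound 3, `CC1(C)[C@@H](Nc2cc(NCc3cnccc3C(F)(F)F)ncc2C#N)C[C@H]1C(N)=O`, keeps the amide but changes the ring: 3-carbamoyl-2,2-dimethylcyclobutyl in place of 4-(methylcarbamoyl)cyclohexyl on a nitrogen on an aromatic ring. Within the data shown here, no measured step covers a change of this kind, so the expectation leans on compound 2 staying roughly where it is, with some chance that the amide-bearing cyclobutyl does better than compound 2 at 1600 nM. Compound 3 is therefore expected to land near 800 nM, within 150 nM to 4000 nM, which means an expected step of a 2.0-fold lower number from compound 2 to compound 3 (0.30 log units; within the scatter).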

Compound 3, half-maximal inhibitory concentration: 4500 nM
Compound 3: the middle estimate sits 5.6-fold (0.75 log units) below what was measured; the measured number lies above the stated range.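

The ring that carries the amide matters at this position, not only the presence of an amide: in this assay, 3-carbamoyl-2,2-dimethylcyclobutyl in place of 4-(methylcarbamoyl)cyclohexyl gives a 2.8-fold higher number from compound 2 to compound 3 (0.45 log units; beyond the scatter). Set against 3-hydroxycyclobutyl, the same group still gives an at least 2.2-fold lower number from compound 1 to compound 3 (0.34 log units; beyond the scatter), so this amide-bearing cyclobutyl keeps part of the gain. Compound 1 gives > 10000 nM, which is a limit of the assay and not a number, so this second step has only a lower end: the limit of > 10000 nM in this assay, at which 1 of the 3 values shown sits.

The change from the cyclohexyl to the cyclobutyl group alters the ring size, adds two methyl groups and removes the methyl on the amide all at once, so the compounds shown cannot separate these changes. As far as these compounds go, how a carboxylic acid or an amine in place of the amide would read in this assay also remains open.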